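The source may report more compounds than this note shows. Statements on the series, on what has been measured and on what is new or still open speak of the compounds shown alone.

Compound 1, `Cc1c(NC(=O)COc2ccc(/C=C3\SC(=O)NC3=O)cc2)c(=O)n(-c2ccccc2)n1C`, gives < 100000 nM in a functional assay on K562 cells (Homo sapiens) for cytotoxicity, read by sulforhodamine B assay, with a stated time of 48 h (a lower number here means a stronger inhibitor of growth, a higher number a weaker inhibitor of growth), a limit rather than a number.
Compound 2, `Cc1cnc(NC(=O)COc2ccc(/C=C3\SC(=O)NC3=O)cc2)s1`, gives < 100000 nM in this assay, again a limit.
Compound 3, `O=C(COc1ccc(/C=C2\SC(=O)NC2=O)cc1)Nc1cccc(C(F)(F)F)c1`, gives < 100000 nM in this assay, likewise a limit.

All three measured compounds share the same core, a benzylidene thiazolidinedione joined through an ether and an amide to a varying aromatic group. For compound 2 the assay reports only a limit and no number, so its standing among the three cannot be placed; the limit of < 100000 nM in this assay, at which 3 of the 3 values shown sit, is the whole of what the three measurements show, and none of them can be said to be stronger or weaker than another.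

Compound 4, `O=C(COc1ccc(/C=C2\SC(=O)NC2=O)cc1)Nc1ncc([N+](=O)[O-])s1`, is the not yet measured member. It differs from compound 2 in one spot: nitro in place of methyl on an aromatic carbon. Among the measured compounds shown here, no measured pair in the set isolates this change, so nothing here says how large a step it makes or in which direction.

With nothing to lean on, the expected step from compound 2 to compound 4 is a step that the limit leaves unreadable from compound 2 to compound 4, which amounts to no change beyond the scatter. Compound 4 is therefore estimated at 30000 nM, with a range from 3000 nM to 100000 nM, and a real chance that the assay again reports only a limit.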

Compound 4, concentration for total growth inhibition: < 100000 nM
Compound 4: a limit, no number; the forecaster's own chance of this, stated with the estimate: 70%; the middle value does not contradict the limit.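

Compound 2 and compound 4 each give only a limit in this assay, so no step can be read between them, and nitro in place of methyl shows no readable size or direction: the limit of < 100000 nM in this assay, at which 4 of the 4 values shown sit.

The compounds shown leave open how strongly each one actually inhibits growth, and whether the varying aromatic group matters in this assay at all.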